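A few compounds are considered here, and "the series" means these few. Any claim that something is new, unique, unknown or untested is made for them only; others in the source may bear on it.

Three ketones that share a saturated seven-carbon chain ending in a phenyl ring have been tested in an assay on HEK-293T cells for inhibition of diacylglycerol lipase-alpha (Homo sapiens), read by colorimetric assay; a lower number here means a stronger inhibitor, a higher number a weaker inhibitor. Compound 1 `O=C(CCCCCCc1ccccc1)c1nncs1` carries a 1,3,4-thiadiazol-2-yl group on the carbonyl carbon, compound 2 `COc1coc(C(=O)CCCCCCc2ccccc2)n1` a 4-methoxy-1,3-oxazol-2-yl group, and compound 3 `CSc1coc(C(=O)CCCCCCc2ccccc2)n1` a 4-(methylsulfanyl)-1,3-oxazol-2-yl group. In this assay compound 1 gives only a limit, > 10000 nM. Compound 2 likewise gives only a limit, > 10000 nM. Compound 3 also stands at a limit, > 10000 nM. The steps a step that the two limits leave unreadable from compound 1 to compound 2, a step that the two limits leave unreadable from compound 1 to compound 3 and a step that the two limits leave unreadable from compound 2 to compound 3 cannot be sized, because of the limit of > 10000 nM in this assay, at which 3 of the 3 values shown sit.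

Compound 4 `O=C(CCCCCCc1ccccc1)c1ncno1` has not been measured. The change from compound 3 is 1,2,4-oxadiazol-5-yl in place of 4-(methylsulfanyl)-1,3-oxazol-2-yl on a carbonyl carbon. Among the measured compounds shown here, none of the measured steps gives a readable size, so the direction and size of the step in this assay remain open. Compound 4 is estimated at 1500 nM, within 100 nM to 10000 nM, which would mean an expected step of an at least 6.6-fold lower number from compound 3 to compound 4 (0.82 log units; beyond the scatter).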

Compound 4, half-maximal inhibitory concentration: > 10000 nM
Compound 4 gave a limit, no number; the forecaster's own chance of this, stated with the estimate: 40%; at least 6.6-fold (0.82 log units) between middle value and limit.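

In this assay compound 4 also gives only a limit, > 10000 nM, so no step linking it to compound 1, compound 2 or compound 3 can be read: the limit of > 10000 nM in this assay, at which 4 of the 4 values shown sit.

The compounds shown leave open whether the groups on the carbonyl carbon differ at all in this assay.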